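The compounds below may be only part of what the source reports. "The series", "measured", "known", "first", "only" and "open" are said of these compounds alone.

Measured compounds:
- compound 1, `Cc1ccc(-c2cnc(C)n2C)cc1NC(=O)c1ccc(OCc2ccccn2)cc1`: in a physicochemical assay for lipophilicity (a lower number here means a more polar compound, a higher number a more lipophilic compound), compound 1 gives 2.8
- compound 2, `Cc1ncc(-c2cc(NC(=O)c3ccc(OCc4ccccn4)cc3)c(C)cc2C)[nH]1`: in this assay compound 2 gives 2.8
- compound 3, `Cc1cc(F)c(-c2ncc[nH]2)cc1NC(=O)c1ccc(OCc2ccccn2)cc1`: in this assay compound 3 gives 3

Compound 2 stands level with compound 1 at the digits shown, the two together the lowest of the three numbers, and its gap to compound 3 lies within the scatter, so nothing here separates the three beyond repeat variation.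

Compound 4, `Cc1cc(C)c(-c2cccc(N)n2)cc1NC(=O)c1ccc(OCc2ccccn2)cc1`, has not been measured. It arises from compound 2 by one change: 6-aminopyridin-2-yl in place of 2-methyl-1H-imidazol-5-yl on an aromatic carbon. For the measured compounds named here, no step between two measured compounds mirrors this exchange, so the expectation rests on the shared core alone. A small step upward, at the edge of the scatter, is expected; the step from compound 2 to compound 4 is estimated as a number 0.30 log units higher from compound 2 to compound 4 (within the scatter). Compound 4 is therefore expected to give about 3.1, within a range from 2.6 to 3.6.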

Compound 4, distribution coefficient: > 3
Compound 4 was reported as a limit; the forecaster's own chance of this, stated with the estimate: 2%; the middle value does not contradict the limit.
By their numbers in this assay, from the lowest: compounds 1, 2 and 3 (each within the scatter of the next).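

In this assay compound 4 gives > 3, which is a limit of the assay and not a number. For the compounds shown here, this is the first reading of 6-aminopyridin-2-yl on this aromatic carbon, ortho to one methyl group and para to another, and the exchange gives a number at least 0.20 log units higher from compound 2 to compound 4 (that floor lies within the scatter). Only a floor can be read for this step, so its full size remains unknown: the limit of > 3 in this assay, at which 1 of the 4 values shown sits.

Whether the ring or its amine accounts for the step remains open. A plain pyridin-2-yl on this carbon would separate the two, and a carboxylic acid there would test a very different group.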